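Fluorophenyl in Place of Methylpyridyl at a Cytotoxicity Limit

The source may hold more compounds than are shown below. What is called first, only, known or untested is meant among the compounds shown, and "the series" means these compounds.

Compound 3 `Cc1cncc(-c2ccc3[nH]c(=O)nc(-c4ccccc4)c3c2)c1` gives in an ADME assay on L6 cells (Rattus norvegicus) for cytotoxicity, read by fluorescence and resazurin assay, with a stated time of 72 h (on this read-out higher numbers stand for an effect only at larger amounts of compound and lower numbers for an effect already at smaller amounts), only a limit, > 50000 nM. Compound 1 `Cc1cc(-c2ccc3[nH]c(=O)nc(-c4ccccc4)c3c2)ccn1` likewise gives a limit in this assay, > 50000 nM. Compound 2 `Cc1ccc(-c2ccc3[nH]c(=O)nc(-c4ccccc4)c3c2)cn1` also gives a limit there, > 50000 nM. The steps a step that the two limits leave unreadable from compound 1 to compound 2, a step that the two limits leave unreadable from compound 1 to compound 3 and a step that the two limits leave unreadable from compound 2 to compound 3 cannot be read because of the limit of > 50000 nM in this assay, at which 3 of the 3 values shown sit. Compound 4 `O=c1nc(-c2ccccc2)c2cc(-c3cccc(F)c3)ccc2[nH]1` differs from compound 3 by 3-fluorophenyl in place of 5-methylpyridin-3-yl on an aromatic carbon. Going by the values given here, no measured step bears on this change in a readable way. Compound 4 is therefore expected to sit at the same limit in this assay, with a step of a number no higher from compound 3 to compound 4 (the limit leaves the size open) estimated to lie within the scatter. The value estimated for compound 4 is 50000 nM, with a range from 20000 nM to 120000 nM.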

Compound 4, half-maximal effective concentration: 23000 nM
Beside the measured number, compound 4's estimate is 2.2-fold (0.34 log units) above it, and the stated range covers the measured number.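

In this assay, going by these compounds alone, 3-fluorophenyl at this position gives the only number that comes off the limit, with an at least 2.1-fold lower number from compound 3 to compound 4 (0.33 log units; beyond the scatter), an at least 2.1-fold lower number from compound 2 to compound 4 (0.33 log units; beyond the scatter) and an at least 2.1-fold lower number from compound 1 to compound 4 (0.33 log units; beyond the scatter). The group on this aromatic carbon can therefore shift the read-out, which the three methylpyridyl compounds could not show among themselves. The true size of each step stays open: the limit of > 50000 nM in this assay, at which 3 of the 4 values shown sit.

The compounds shown do not separate the effect of the fluorine from that of losing the ring nitrogen and the methyl. Going by these compounds, how an amine or a carboxylic acid on this ring would read in this assay also remains open.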